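The source may hold more compounds than are shown below. What is called first, only, known or untested is meant among the compounds shown, and "the series" means these compounds.

Compound 3 `COc1cc(O)ccc1N1CCN(CC(O)COc2ccc(O)c3ccccc23)CC1` gives 45700 nM in a functional assay on PC-3 cells (Homo sapiens) for antiproliferative activity, read by MTT assay, with a stated time of 48 h (on this read-out lower numbers stand for stronger inhibition and higher numbers for weaker inhibition), the highest number among the three measured compounds. Compound 1 `Oc1ccc(N2CCN(CC(O)COc3cccc4ccccc34)CC2)c(O)c1` gives 30300 nM, and compound 2 `COc1cc(O)ccc1N1CCN(CC(O)COc2cccc3ccccc23)CC1` gives 24400 nM; all three lie within the scatter of one another. Compound 4 `Oc1ccccc1N1CCN(CC(O)COc2ccc(O)c3ccccc23)CC1` differs from compound 3 by 2-hydroxyphenyl in place of 4-hydroxy-2-methoxyphenyl on an amine nitrogen in a ring. Within the data shown here, no measured step touches this exact exchange, but the two steps, a 1.2-fold lower number from compound 1 to compound 2 (0.09 log units; within the scatter) and a 1.9-fold higher number from compound 2 to compound 3 (0.27 log units; within the scatter), both stayed within the scatter, so changes of this kind on the phenyl ring and on the naphthalene have so far moved the read-out little. Compound 4 is therefore expected to show a step of a 1.3-fold lower number from compound 3 to compound 4 (0.12 log units; within the scatter), not beyond the scatter, with an estimated value of 35000 nM and a range from 15000 nM to 80000 nM.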

Compound 4, half-maximal inhibitory concentration: 26100 nM
Compound 4: middle estimate off by 1.3-fold (0.13 log units), on the high side, and the stated range covers the measured number.
By their numbers in this assay, from the lowest: compounds 2, 4, 1 and 3 (each within the scatter of the next).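

Replacing 4-hydroxy-2-methoxyphenyl with 2-hydroxyphenyl on the amine nitrogen in the ring gives a 1.8-fold lower number from compound 3 to compound 4 (0.24 log units; within the scatter) in this assay. The earlier steps shown here each replaced a single hydrogen, whereas this one exchanges the whole group on that nitrogen, and the number still stays within the scatter. No available evidence speaks to what lies behind this result. All four compounds carry only hydroxy or methoxy groups on that phenyl ring. Going by these compounds, whether an amine or a carboxylic acid there would move the number beyond the scatter remains open.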